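Series notes: amine substituent swap on the sulfamate amide

A few compounds are considered here, and "the series" means these few. Any claim that something is new, unique, unknown or untested is made for them only; others in the source may bear on it.

Of the compounds shown here, three have been tested in an assay on HEK293 cells for inhibition of Steryl-sulfatase (Homo sapiens), tested at 1 uM; on this read-out lower numbers stand for a weaker effect and higher numbers for a stronger effect at the one concentration tested. Compound 2 `CC(C)CCN(CCC(C)C)c1ccc(C(=O)N2CCc3ccc(OS(N)(=O)=O)cc3C2)cc1` gives 90.8%, the highest of the three numbers. Compound 3 `CCN(Cc1ccccc1)Cc1ccc(S(=O)(=O)N2CCc3ccc(OS(N)(=O)=O)cc3C2)cc1` gives 31% in this assay, and compound 1 `CN(C)CCCN(Cc1ccccc1)c1cccc(C(=O)N2CCc3ccc(OS(N)(=O)=O)cc3C2)c1` gives 26%; both gaps to compound 2 lie beyond the scatter, so compound 2 stands clearly above the other two. Among the compounds with values here, no single-point step between measured compounds is available, since compounds 1 and 3 differ from compound 2 in more than one place.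

Compound 4 `CCN(Cc1ccc(F)cc1)c1ccc(C(=O)N2CCc3ccc(OS(N)(=O)=O)cc3C2)cc1` is not yet measured in this assay. It differs from compound 2 as follows: ethyl(4-fluorobenzyl)amino in place of diisopentylamino on an aromatic carbon

The two compounds that carry a benzyl-type group, compound 1 with 26% and compound 3 with 31%, sit well below compound 2, but neither is a clean comparison. The expectation is therefore a downward step, of a size set loosely by those two values rather than by a clean pair. For compound 4 the estimate in this assay is 55%, within a range of 25% to 85%. This estimate means an expected step of a number 35.8 percentage points lower from compound 2 to compound 4 (beyond the scatter), beyond the scatter.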

Compound 4, a percentage reported as inhibition, at one concentration (the size of the read-out at that concentration, not a potency): 91.2%
For compound 4 the middle estimate is 36.2 percentage points below the measured one, outside the stated range (above it).
By their numbers in this assay, from the lowest: compounds 1 and 3 (each within the scatter of the next); then compounds 2 and 4 (each within the scatter of the next).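

In this assay, within the data shown here, ethyl(4-fluorobenzyl)amino in place of diisopentylamino on an aromatic carbon, para to a large group, gives a number 0.4 percentage points higher from compound 2 to compound 4 (within the scatter), the first one-place step in this set and one that shows no readable change at this position. As far as these compounds go, the swap replaces two branched chains with a group holding one six-membered aromatic ring of carbon only and a fluorine, at 11 heavy atoms on both sides, so this position accepts both amine substituents at the one concentration tested, though the read-out is not a potency and any difference in potency between the two stays unknown. No supporting data bear on why the two groups read alike.

Still open, from the compounds shown here alone, is what a plain benzyl without the fluorine would give on this amine, and whether a carboxylic acid on that ring or a longer chain in place of the ethyl would be accepted in the same way. Compound 1 and compound 3 each differ from compound 2 in more than one place, so their steps cannot be read and what separates them from the others remains unassigned.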